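Replacing a Sulfanyl Group on the Shared Core

The compounds below may be only part of what the source reports. "The series", "measured", "known", "first", "only" and "open" are said of these compounds alone.

Of the compounds shown here, three built on one core have been measured in an in vitro ADME assay on microsomes (Homo sapiens) for metabolic stability; on this read-out higher numbers stand for a longer-lived compound and lower numbers for a shorter-lived compound. Compound 1 `CCC(CC)Nc1nc(OC)c(-c2ccc(Cl)cc2Cl)nc1C` gives 0.933 h. Among the compounds with values here, compound 2 `CCC(CC)Nc1nc(OC)c(-c2ccc(Cl)cc2Cl)nc1OC` gives 0.267 h in this assay, and the single one-place step recorded, a 3.5-fold lower number from compound 1 to compound 2 (0.54 log units; beyond the scatter), shows that a small change on the shared core can move the number beyond the scatter. Compound 3 `CCc1nc(-c2ccc(Cl)cc2Cl)c(CC)nc1SC(C)CC` gives 0.283 h in this assay, the second highest of the three numbers, within the scatter of compound 2 and beyond it from compound 1.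

Compound 4 `CCc1nc(-c2ccc(Cl)cc2Cl)c(CC)nc1NC(C)CN(C)C` has not yet been measured. It differs from compound 3 in one place: (1-((dimethylamino)methyl)ethyl)amino in place of (sec-butyl)sulfanyl on an aromatic carbon. Within the data shown here, no measured step covers this change; the one recorded step concerns a different group, so it bears on compound 4 only by showing how far a single substitution can shift the number. Among the measured compounds shown here, compound 1 and compound 3 differ in more than one place, so their two values show only that compound 1 sits higher. The expectation for compound 4 is therefore a small upward step, a 1.6-fold higher number from compound 3 to compound 4 (0.20 log units; within the scatter), not firmly beyond the scatter. Compound 4 is estimated at 0.45 h in this assay, with a range from 0.18 h to 1.1 h.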

Compound 4, half-life: 0.117 h
Compound 4: the middle estimate sits 3.8-fold (0.59 log units) above what was measured; measured number outside the range, below it.
By their numbers in this assay, from the lowest: compound 4; then compounds 2 and 3 (each within the scatter of the next); then compound 1.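

In this assay, putting (1-((dimethylamino)methyl)ethyl)amino in place of (sec-butyl)sulfanyl, on the aromatic carbon next to the ring nitrogen, gives a 2.4-fold lower number from compound 3 to compound 4 (0.38 log units; beyond the scatter), so the number responds to the group held at this position, and for this exchange it moves toward a shorter-lived compound. The exchange alters two things at once, the atom that links the chain to the core and the chain itself, which now ends in a dimethylamino group, and this single step cannot separate the two. Nothing in the data offers an explanation for this step.

From the compounds shown here alone, what remains open is how much of the step belongs to the link alone: a plain sec-butylamino group at this position, with the chain of the leaving group kept and only the sulfur exchanged for nitrogen, would divide the step into its two parts. Going by these compounds, it is also open whether the end of the chain matters, which a chain ending in a hydroxyl group or a morpholine ring in place of the dimethylamino group would begin to show.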